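Shortening the Linker of Compound 1: What to Expect

The source may report more compounds than this note shows. Statements on the series, on what has been measured and on what is new or still open speak of the compounds shown alone.

Within the data shown here, compound 1, `CC/N=C(\S)NCCCCCn1nc(-c2ccccc2)ccc1=O`, gives the highest number of the three compounds measured so far in a functional assay on the whole organism with Rattus norvegicus as the target, at a dose of 100 mg/kg (a lower number here means less inhibition, a higher number more inhibition at the dose given (going by the name of the read-out)), where compound 1 gives 66.4%. The two other measured compounds replace the sulfur-bearing group on the amine nitrogen with a nitrile-bearing one: compound 2, `CCC/N=C(/NC#N)NCCCCCn1nc(-c2ccccc2)ccc1=O`, gives 27.5%, and compound 3, `CC/N=C(/NC#N)NCCCCCn1nc(-c2ccccc2)ccc1=O`, gives 48.2%, so inhibition fell a number 38.9 percentage points lower from compound 1 to compound 2 (beyond the scatter) and a number 18.2 percentage points lower from compound 1 to compound 3 (beyond the scatter). Between those two it rose a number 20.7 percentage points higher from compound 2 to compound 3 (beyond the scatter), the change there being hydrogen in place of methyl on a saturated chain carbon, two bonds along the chain from a double-bonded nitrogen.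

Compound 4, `C/N=C(\S)NCCCn1nc(-c2ccccc2)ccc1=O`, differs from compound 1 differently: a group of 5 heavy atoms (2 carbon, 2 nitrogen, 1 sulfur; no ring) in place of a group of 8 heavy atoms (5 carbon, 2 nitrogen, 1 sulfur; no ring), on a saturated chain carbon, three bonds along the chain from an aromatic nitrogen. The sulfur-bearing group stays, but the chain between the shared core and that group is shorter. Among the measured compounds shown here, no measured step touches this place; the only loose guide is that shortening a chain once gave a modest rise. For compound 4 the expected step is therefore a number 8.4 percentage points lower from compound 1 to compound 4 (within the scatter), judged to lie within the scatter but with wide uncertainty. Compound 4 is estimated at 58%, in a range from 32% to 80%.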

Compound 4, a percentage reported as inhibition, in the whole organism at one dose (the size of the read-out at that dose, not a potency): 38.9%
Compound 4: the middle estimate sits 19.1 percentage points above what was measured; low and high end bracket the measured number.
By their numbers in this assay, from the lowest: compound 2; then compounds 4 and 3 (each within the scatter of the next); then compound 1.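

In this assay, the only change shown on the saturated chain carrying the sulfur-bearing group gives a number 27.5 percentage points lower from compound 1 to compound 4 (beyond the scatter) and so lowers inhibition. The earlier shortening at the far end of a side chain, a number 20.7 percentage points higher from compound 2 to compound 3 (beyond the scatter), went the other way, so making a group smaller does not raise the number at every place in these compounds. The swap also puts methyl where compound 1 has ethyl, so this one step cannot be divided between the shorter chain and that end group. Nothing available explains the fall.

From the compounds shown here alone, it stays open how methyl alone would read on the chain of compound 1, and how ethyl would read on the chain of compound 4. A longer chain, or an amine in place of the sulfur-bearing group, also remains untested among the compounds shown.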